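The compounds below may be only part of what the source reports. "The series", "measured", "known", "first", "only" and "open" are said of these compounds alone.

Working notes on the series.

Compound 1 `C=C1C2=C(C(=O)N1OC)[C@H](OC(=O)CSc1nc3ccccc3s1)[C@@](C)(O)[C@H](CCCCC)O2` gives 2000 nM in a functional assay on RPMI-8226 cells (Homo sapiens) for cytotoxicity, read by MTT assay, with a stated time of 72 h (on this read-out higher numbers stand for weaker inhibition and lower numbers for stronger inhibition), the lowest of the three numbers recorded so far. Compound 2 `C=C1C2=C(C(=O)N1OC)[C@H](O)[C@@](C)(O)[C@H](CCCCC)O2`, which carries hydrogen on the oxygen of the saturated carbon, gives 9300 nM in this assay. Compound 3 `C=C1C2=C(C(=O)N1OC)[C@H](OC(=O)CCCCCl)[C@@](C)(O)[C@H](CCCCC)O2` gives 4300 nM in this assay. The two measured steps are a 2.2-fold higher number from compound 1 to compound 3 (0.33 log units; beyond the scatter) and a 2.2-fold lower number from compound 2 to compound 3 (0.34 log units; beyond the scatter); both concern the ester arm as a whole, and neither alters only the aromatic part of the side chain.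

Compound 4 `C=C1C2=C(C(=O)N1OC)[C@H](OC(=O)CSc1nc3ccccc3[nH]1)[C@@](C)(O)[C@H](CCCCC)O2` is to be measured in this assay. Relative to compound 1 the change is 1H-benzimidazol-2-yl in place of 1,3-benzothiazol-2-yl on a sulfur. Among the compounds with values here, no measured step bears directly on this exchange; the nearest comparison, from compound 1 to compound 3, shows that replacing the heteroaryl-bearing arm by a chloroalkyl chain moves the number only modestly. The exchange is therefore expected to give at most a modest step, with no confident direction, estimated as a 1.3-fold higher number from compound 1 to compound 4 (0.10 log units; within the scatter). Compound 4 is estimated at 2500 nM, with a range from 1000 nM to 6000 nM.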

Compound 4, half-maximal inhibitory concentration: 4300 nM
Beside the measured number, compound 4's estimate is 1.7-fold (0.24 log units) below it, within the range that was stated.
By their numbers in this assay, from the lowest: compound 1; then compounds 3 and 4 (each within the scatter of the next); then compound 2.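

Within the data shown here, the exchange of 1,3-benzothiazol-2-yl for 1H-benzimidazol-2-yl on a sulfur gives the first reading on the aromatic part of the side chain: in this assay it produces a 2.2-fold higher number from compound 1 to compound 4 (0.33 log units; beyond the scatter) and so shows that this position responds to the heteroaryl group itself, not only to the ester arm as a whole. Set against the chloroalkyl arm, the (1H-benzimidazol-2-yl)sulfanyl arm gives no change at the digits printed from compound 3 to compound 4 (within the scatter) and cannot be told apart from the 3-chloropropyl arm of compound 3 in this assay, so among the three esters only compound 1 stands apart. Nothing available explains the step from compound 1 to compound 4.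

The compounds shown leave open whether a 1-methyl-1H-benzimidazol-2-yl group on the sulfur would read with compound 1 or with compound 4. They also leave open how a 1,3-benzoxazol-2-yl or a plain phenyl group on that sulfur would read.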